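The source may hold more compounds than are shown below. What is called first, only, known or untested is meant among the compounds shown, and "the series" means these compounds.

Working notes on the series. Two compounds have numbers in a functional assay on MDA-MB-231 cells (Homo sapiens) for inhibition, read by sulforhodamine B assay, with a stated time of 48 h; a lower number here means a stronger inhibitor of growth, a higher number a weaker inhibitor of growth. Compound 1 `O=C(Nc1cccc(-n2cc(-c3ccncc3)c(-c3ccc(Cl)c(O)c3)n2)c1)Nc1ccc(Cl)c(Cl)c1` carries the hydroxy variant of the aryl group and the dichloro urea end; in this assay compound 1 gives 8330 nM. Compound 2 `COc1cc(-c2nn(-c3cccc(NC(=O)Nc4ccc(Cl)c(C(F)(F)F)c4)c3)cc2-c2ccncc2)ccc1Cl` carries the methoxy variant together with the chloro-trifluoromethyl urea end; in this assay compound 2 gives 2600 nM, the lowest of the two numbers, with compound 1 standing beyond the scatter above it. Among the measured compounds shown here, no pair here differs in one place only, so no single step is measured.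

Compound 3 `O=C(Nc1cccc(-n2cc(-c3ccncc3)c(-c3ccc(Cl)c(O)c3)n2)c1)Nc1ccc(Cl)c(C(F)(F)F)c1` is the next compound, not yet measured. It keeps the urea end of compound 2 and changes only one point: hydrogen in place of methyl on an oxygen on an aromatic ring. For the measured compounds named here, no measured step tells the size of this change on its own. Going by the values given here, the expectation is for a small shift toward a higher number in this assay, of the size a 1.7-fold higher number from compound 2 to compound 3 (0.24 log units; within the scatter), because compound 1, the only hydroxy compound, gives 8330 nM. Compound 3 is thus estimated at 4500 nM, with a range from 1500 nM to 13000 nM.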

Compound 3, concentration for total growth inhibition: 1440 nM
Compound 3: the middle estimate sits 3.1-fold (0.49 log units) above what was measured; measured number below the stated range.
By their numbers in this assay, from the lowest: compounds 3 and 2 (each within the scatter of the next); then compound 1.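

Methoxy to hydroxy on the 4-chloro-3-methoxyphenyl group gives a 1.8-fold lower number from compound 2 to compound 3 (0.26 log units; within the scatter) in this assay and, with this urea end, the two groups cannot be told apart at this position. Among the compounds shown here, with the hydroxy group held, the change of trifluoromethyl in place of chloro on an aromatic carbon gives a 5.8-fold lower number from compound 1 to compound 3 (0.76 log units; beyond the scatter) and is the first single step beyond the scatter, so the hydroxy group by itself does not carry the high number of compound 1. Nothing measured here gives a cause for either step.

The compounds shown leave open whether the methoxy to hydroxy step has the same size with the dichloro urea end. They also leave open what an amine or a longer chain such as ethoxy on this aromatic ring position would give.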